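The compounds below may be only part of what the source reports. "The series", "measured", "known", "first", "only" and "open" are said of these compounds alone.

Working notes on the series. Among the measured compounds shown here, compound 1 `CCCCN(CC)c1cc(C)nc2c1NC(=O)CN2c1ccc(Br)cc1Br` is the one member of the set with a number: in an assay on HEK-293T cells for displacement of a labelled ligand from corticotropin-releasing factor receptor 2 (Homo sapiens), read by scintillation counting, with a stated time of 2 h, tested at 1 uM (on this read-out higher numbers stand for more inhibition at the one concentration tested (going by the name of the read-out) and lower numbers for less inhibition), compound 1 gives 9.4%. For the measured compounds named here, compound 2 `CCCCN(CC)c1cc(C)nc2c1NC(=O)CN2c1ccc(Cl)cc1Br` was run in this assay and is recorded there as "not determined" (no result reported), and compound 3 `CCCCN(CC)c1cc(C)nc2c1NC(=O)CN2c1ccc(Cl)cc1C` is likewise recorded in this assay as "not determined" (no result reported), so compound 3 stands without a number, and the set as a whole rests on the single figure for compound 1. Compound 4 `CCCCN(CC)c1cc(C)nc2c1NC(=O)CN2c1ccc(C)cc1Br` has not been measured. It differs from compound 3 in one place: 2-bromo-4-methylphenyl in place of 4-chloro-2-methylphenyl on a nitrogen on an aromatic ring in a ring. Going by the values given here, with neither compound 3 nor compound 2 carrying a number, the step from compound 3 to compound 4 cannot be fixed from the set itself; the only anchor is compound 1, which in this assay sits at the low end of the read-out with 9.4%. For the step in this assay the expectation is no change beyond the usual scatter, in either direction. Compound 4 is therefore expected to give about 10% in this assay, estimated within 0% to 30%.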

Compound 4, a percentage reported as inhibition, at one concentration (the size of the read-out at that concentration, not a potency): 5.5%
For compound 4 the middle estimate is 4.5 percentage points above the measured one; the range from low to high includes it.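

In this assay, among the compounds shown here, methyl in place of bromo on an aromatic carbon gives a number 3.9 percentage points lower from compound 1 to compound 4 (within the scatter), the first measured step, so exchanging these two groups on the aromatic ring does not move the read-out beyond the scatter and both compounds remain at the low end. Steps involving compound 2 or compound 3 cannot be read, which leaves the change from 4-chloro-2-methylphenyl to 2-bromo-4-methylphenyl without a measured size. No measurement at hand bears on the reason for this result.

From the compounds shown here alone, whether any substituent on this ring can raise the inhibition remains open, as bromo and methyl are the only two compared here, and an amine or a carboxylic acid in their place would test this. Also open, going by these compounds, is whether a longer chain on the amino nitrogen of the shared core would change the read-out.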